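The source may hold more compounds than are shown below. What is called first, only, known or untested is meant among the compounds shown, and "the series" means these compounds.

Measured compounds:
compound 1, `Cc1c(C)c2c(c(C)c1O)CCC(C)(C(=O)Nc1ccncc1)O2`: 2300 nM
compound 2, `Cc1c(C)c2c(c(C)c1O)CCC(C)(C(=O)Nc1ccccn1)O2`: 1800 nM

In a functional assay (brain) for inhibition, with Rattus norvegicus as the target (on this read-out higher numbers stand for weaker inhibition and lower numbers for stronger inhibition), compound 1 gives 2300 nM and compound 2 gives 1800 nM. Compound 2 stands within the scatter of compound 1, the step of a 1.3-fold lower number from compound 1 to compound 2 (0.11 log units; within the scatter) being too small to read as a change. Compound 3, `Cc1c(C)c2c(c(C)c1O)CCC(C)(C(=O)NCCCc1ccccc1)O2`, differs from compound 2 in one place: 3-phenylpropyl in place of pyridin-2-yl on an amide-type nitrogen. Among the measured compounds shown here, the only measured step exchanges one pyridyl for another on the amide-type nitrogen; no measured step replaces a pyridin-2-yl with a 3-phenylpropyl, so the data give no footing for a direction. The step expected is a 1.1-fold higher number from compound 2 to compound 3 (0.05 log units; within the scatter), none beyond the scatter, with wide uncertainty. Compound 3 is estimated at 2000 nM, in a range from 500 nM to 8000 nM.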

Compound 3, half-maximal inhibitory concentration: 1000 nM
For compound 3 the middle estimate is 2.0-fold (0.30 log units) above the measured one; measured number inside the range.
By their numbers in this assay, from the lowest: compounds 3, 2 and 1 (each within the scatter of the next, the first and the last beyond it).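

Among the compounds shown here, on the amide-type nitrogen in this assay, 3-phenylpropyl replaces a pyridyl group directly on that nitrogen with no loss: against pyridin-2-yl the result is a 1.8-fold lower number from compound 2 to compound 3 (0.26 log units; within the scatter), and against pyridin-4-yl it is a 2.3-fold lower number from compound 1 to compound 3 (0.36 log units; beyond the scatter), the first step at this place to pass the scatter. Nothing at hand accounts for this step.

The compounds shown do not separate the carbon chain from the carbon-only ring, as neither benzyl nor 3-(pyridin-2-yl)propyl is among them. On these data alone, how a chain carrying an amine or a carboxylic acid would read also remains open.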